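The source may hold more compounds than are shown below. What is called first, only, known or untested is meant among the compounds shown, and "the series" means these compounds.

Measured in a functional assay on K562 cells (Homo sapiens) for antiproliferative activity, with a stated time of 72 h; on this read-out lower numbers stand for stronger inhibition and higher numbers for weaker inhibition:
compound 1 `OC[C@H]1O[C@@H](n2cnc3c(NCc4ccccc4Br)ncnc32)[C@H](O)[C@@H]1O`: 10000 nM
compound 2 `COc1cccc(CNc2ncnc3c2ncn3[C@@H]2O[C@H](CO)[C@@H](O)[C@H]2O)c1`: > 166000 nM, a limit of the assay

Compound 2 has no number on this read-out, only the limit > 166000 nM. Compound 3 `OC[C@H]1O[C@@H](n2cnc3c(NCc4ccc(F)c(F)c4F)ncnc32)[C@H](O)[C@@H]1O` keeps the shared core and differs from compound 2 in one place: 2,3,4-trifluorophenyl in place of 3-methoxyphenyl on a saturated chain carbon bound to a nitrogen on an aromatic ring. A single measured step bears on this place, an at least 16-fold higher number from compound 1 to compound 2 (1.22 log units; beyond the scatter), which is large and beyond the scatter. There, 3-methoxyphenyl replaced 2-bromophenyl. Compound 3 gives up that 3-methoxyphenyl, and its ring carries fluorine, as the ring of compound 1 carries bromine. A sizeable move towards lower numbers in this assay is therefore expected, back towards compound 1, though a further limit remains possible. The estimated step is an at least 5.5-fold lower number from compound 2 to compound 3 (0.74 log units; beyond the scatter). For compound 3 the expected value is 30000 nM, with an estimated range of 6000 nM to 166000 nM.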

Compound 3, half-maximal inhibitory concentration: > 166000 nM
Compound 3 ended at the assay's limit; the forecaster's own chance of this, stated with the estimate: 30%; middle value at least 5.5-fold (0.74 log units) away from the limit.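

In this assay, 2,3,4-trifluorophenyl in place of 2-bromophenyl gives an at least 16-fold higher number from compound 1 to compound 3 (1.22 log units; beyond the scatter), so among these compounds fluorine on the ring does not stand in for the bromine of compound 1. Two unlike rings, 3-methoxyphenyl and 2,3,4-trifluorophenyl, now both leave the read-out at a limit of the assay, and of the three compounds only compound 1, with 2-bromophenyl, gives a number. The step from compound 2 to compound 3 cannot be read, because neither compound has a number: the limit of > 166000 nM in this assay, at which 2 of the 3 values shown sit.

On these data alone, whether the rings of compound 2 and compound 3 differ at all stays open. Also open, as far as these compounds go, is whether compound 1 owes its number to the bromine or to where it sits, which a 2-chlorophenyl, 3-bromophenyl or plain phenyl group at this position would test.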